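The source may hold more compounds than are shown below. What is called first, only, known or untested is meant among the compounds shown, and "the series" means these compounds.

Measured compounds:
- compound 1 `O=C(NN=C(c1ccccn1)c1ccccn1)c1ccc(C(F)(F)F)cc1`: 240 nM in an ADME assay on cells (Homo sapiens) for antiproliferative activity, read by MTT assay; on this read-out lower numbers stand for stronger inhibition and higher numbers for weaker inhibition
- compound 2 `O=C(N/N=C/c1ccccn1)c1ccc(O)cc1`: > 80000 nM in this assay, a limit of the assay and not a number

Compound 1 holds the only actual number shown in this assay; the other entry is a limit (the limit of > 80000 nM in this assay, at which 1 of the 2 values shown sits), so no step between measured compounds can be computed, and compound 2 shares neither the second pyridyl on the hydrazone carbon nor the para substituent of compound 1, so its limit gives no direct reading on either feature.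

Compound 3 `O=C(NN=C(c1ccccn1)c1ccccn1)c1ccccc1` keeps the whole core of compound 1 and differs from it in one place: hydrogen in place of trifluoromethyl on an aromatic carbon. Nothing measured here isolates the contribution of the trifluoromethyl, so the size of the step rests on the assumption that the bis-pyridyl hydrazone part carries most of the activity seen for compound 1. Compound 3 is therefore expected to stay active, with a modest loss in this assay that may not exceed the scatter, the estimated step being a 2.5-fold higher number from compound 1 to compound 3 (0.40 log units; beyond the scatter). For compound 3 the estimate is 600 nM, within 200 nM to 2500 nM.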

Compound 3, half-maximal inhibitory concentration: 3040 nM
Beside the measured number, compound 3's estimate is 5.1-fold (0.70 log units) below it, outside the stated range (above it).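

The aromatic carbon para to a large group is a sensitive place in this series: in this assay, hydrogen in place of trifluoromethyl gives a 13-fold higher number from compound 1 to compound 3 (1.10 log units; beyond the scatter). Activity does not vanish with the trifluoromethyl, as compound 3 still gives a real number of 3040 nM, yet this single substituent separates the two compounds by a large step on an otherwise unchanged core. Nothing shown accounts for the size of this step.

On these data alone, only trifluoromethyl and hydrogen can be compared at this place, so it stays open whether another group there, such as a chlorine atom, a methoxy group, an amine or a carboxylic acid, would sit near compound 1, near compound 3 or outside both. The steps shown touch this one place only, so the contribution of the rest of the shared core also stays open.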